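Replacing a Chloro Group With a Dimethylaminoethylamino Side Chain

A few compounds are considered here, and "the series" means these few. Any claim that something is new, unique, unknown or untested is made for them only; others in the source may bear on it.

Of the compounds shown here, three sharing one core have been measured in a functional assay on BGC-823 cells (Homo sapiens) for cytotoxicity, read by MTT assay, with a stated time of 48 h; a lower number here means a stronger inhibitor, a higher number a weaker inhibitor. Compound 1 `CN(C)CCNc1ccnc2cc(OCc3ccccc3)ccc12` gives 1250 nM, and compound 2 `C=CCOc1ccc2c(NCCN(C)C)ccnc2c1` gives 1360 nM. Compound 3 `CCOc1ccc2c(Cl)ccnc2c1` gives 3910 nM, the highest of the three numbers, and its gaps to both compound 1 and compound 2 lie beyond the scatter. Compound 4 `CCOc1ccc2c(NCCN(C)C)ccnc2c1` differs from compound 3 in one place: (2-(dimethylamino)ethyl)amino in place of chloro on an aromatic carbon. Among the measured compounds shown here, no measured pair covers this exact change, so its size is not known from a direct step. For the measured compounds named here, the only measured step, a 1.1-fold higher number from compound 1 to compound 2 (0.04 log units; within the scatter), concerns the ether substituent instead, and it shows that exchanging phenyl for vinyl there leaves the number essentially unchanged. Compound 4 carries the same (2-(dimethylamino)ethyl)amino group as compound 1 and compound 2 and differs from them only in the ether substituent, so it is expected to land near their numbers and to show a step downward from compound 3 of about a 2.8-fold lower number from compound 3 to compound 4 (0.45 log units; beyond the scatter). Compound 4 is therefore estimated at 1400 nM, with a range from 700 nM to 2800 nM.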

Compound 4, half-maximal inhibitory concentration: 2520 nM
For compound 4 the middle estimate is 1.8-fold (0.26 log units) below the measured one; low and high end bracket the measured number.
By their numbers in this assay, from the lowest: compounds 1, 2, 4 and 3 (each within the scatter of the next, the first and the last beyond it).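

In this assay, the exchange of chloro for (2-(dimethylamino)ethyl)amino on the aromatic carbon opposite the ring nitrogen can now be read directly with the ether held constant: it gives a 1.6-fold lower number from compound 3 to compound 4 (0.19 log units; within the scatter), so this change alone does not move the number beyond the usual scatter. With the side chain kept, the ether substituent now has three members, and methyl in place of vinyl gives a 1.9-fold higher number from compound 2 to compound 4 (0.27 log units; within the scatter), while methyl in place of phenyl gives a 2.0-fold higher number from compound 1 to compound 4 (0.30 log units; within the scatter), so each single exchange among these compounds stays within the scatter. Nothing measured here offers an explanation for the size of these steps.

The compounds shown leave open whether a longer chain between the two nitrogens, as in (3-(dimethylamino)propyl)amino, or a simple amine on the same aromatic carbon would set a compound apart from compound 3 beyond the scatter. As far as these compounds go, it also remains open whether chloro in place of the side chain would give a similarly small step when the ether carries the phenyl of compound 1 or the vinyl of compound 2.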